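Isopropyl for methyl on the chain carbon

The source may hold more compounds than are shown below. What is called first, only, known or untested is meant among the compounds shown, and "the series" means these compounds.

Compound 1 `CC(C)[C@H](NC(=O)c1cc(Cl)ccc1O)C(=O)Nc1ccc(Cl)cc1` sits at a limit in a functional assay on K562 cells (Homo sapiens) for cytotoxicity, with a stated time of 72 h; a lower number here means a stronger inhibitor, a higher number a weaker inhibitor: > 20000 nM.
Compound 2 `O=C(CNC(=O)c1cc(Cl)ccc1O)Nc1cccc(Cl)c1` sits at a limit: > 10000 nM.
Compound 3 `C[C@H](NC(=O)c1cc(Cl)ccc1O)C(=O)Nc1cccc(Cl)c1` sits at a limit: > 10000 nM.

Compound 3 therefore stands at the limit described in the limit of > 10000 nM in this assay, at which 2 of the 3 values shown sit, and none of the three values shown is a number. Compound 4 `CC(C)[C@H](NC(=O)c1cc(Cl)ccc1O)C(=O)Nc1cccc(Cl)c1` differs from compound 3 by isopropyl in place of methyl on a saturated chain carbon bound to an amide-type nitrogen and a carbonyl carbon. For the measured compounds named here, the one measured step along this chain, a step that the two limits leave unreadable from compound 2 to compound 3, is unreadable, and compound 1, which carries the isopropyl on a differently substituted anilide, also gives only a limit (the limit of > 20000 nM in this assay, at which 1 of the 3 values shown sits). No readable step bears on the change, so compound 4 is expected to return another limit, with the step that the limit leaves unreadable from compound 3 to compound 4 taken as no change beyond scatter. The estimate for compound 4 is 15000 nM, ranging from 5000 nM to 50000 nM.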

Compound 4, half-maximal inhibitory concentration: > 10000 nM
Compound 4: a limit, no number (the forecaster's own chance of this, stated with the estimate: 80%); the middle value is on the limit's open side.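

Compound 4, like compound 1, compound 2 and compound 3, gives only a limit in this assay, so no step among these compounds can be read. The compounds shown leave open whether any change on the saturated chain carbon, or 3-chlorophenyl in place of 4-chlorophenyl, alters the read-out at all.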